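A few compounds are considered here, and "the series" means these few. Any claim that something is new, unique, unknown or untested is made for them only; others in the source may bear on it.

Values in a functional assay on RAW264.7 cells (Mus musculus) for inhibition; on this read-out lower numbers stand for stronger inhibition and higher numbers for weaker inhibition:
- Compound 1 `CCOC(=O)C1=CCCCC1S(=O)(=O)Nc1ccccc1Cl`: 12 nM
- Compound 2 `CCOC(=O)C1=CCCCC1S(=O)(=O)Nc1ccc(Cl)cc1Cl`: 20 nM
- Compound 3 `CCOC(=O)C1=CCCCC1S(=O)(=O)Nc1ccc(C)cc1Cl`: 41 nM

Compound 3, at 41 nM, has the highest number of the three and is the weakest inhibitor here. In compound 4 `CCOC(=O)C1=CCCCC1S(=O)(=O)Nc1ccc(C#N)cc1Cl`, cyano takes the place of methyl on an aromatic carbon (cyano in place of methyl on an aromatic carbon). Within the data shown here, no measured compound carries cyano, so the evidence is indirect. Two modest steps bring methyl in: a 3.4-fold higher number from compound 1 to compound 3 (0.53 log units; beyond the scatter) and a 2.1-fold higher number from compound 2 to compound 3 (0.31 log units; beyond the scatter). Replacing hydrogen with chloro gave a 1.7-fold higher number from compound 1 to compound 2 (0.22 log units; within the scatter). Losing methyl may therefore lower the number slightly. The expected change is small, a 1.4-fold lower number from compound 3 to compound 4 (0.14 log units; within the scatter), and may not exceed the scatter. For compound 4 the estimated value is 30 nM, with an expected range of 10 nM to 90 nM.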

Compound 4, half-maximal inhibitory concentration: 1600 nM
The estimate for compound 4 lay 53-fold (1.73 log units) below the measured number, and the stated range ends below it.
By their numbers in this assay, from the lowest: compounds 1 and 2 (each within the scatter of the next); then compound 3; then compound 4.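

Hydrogen, chloro and methyl at this position, para to a large group, changed the number by modest steps at most, but cyano weakens inhibition sharply in this assay: a 39-fold higher number from compound 3 to compound 4 (1.59 log units; beyond the scatter) and an 80-fold higher number from compound 2 to compound 4 (1.90 log units; beyond the scatter) and a 130-fold higher number from compound 1 to compound 4 (2.12 log units; beyond the scatter). So this position does not accept every small group equally, and swapping a single group here can cost far more than the earlier steps suggested. Nothing available explains the size of this loss. On these data alone, it remains open whether an amine, a carboxylic acid or a methoxy group here would behave like cyano or like methyl. As far as these compounds go, it also remains open whether cyano elsewhere on the aromatic ring would bring a similar loss.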